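A few compounds are considered here, and "the series" means these few. Any claim that something is new, unique, unknown or untested is made for them only; others in the source may bear on it.

Compounds measured so far:
- compound 1, `NCCCNc1c(C(=O)NCc2ccc(F)cc2)nc(Br)c2cccnc12` — in a functional assay on MCF7 cells (Homo sapiens) for cytotoxicity, read by MTT assay, with a stated time of 72 h (on this read-out lower numbers stand for stronger inhibition and higher numbers for weaker inhibition), compound 1 gives 6000 nM
- compound 2, `C[C@H](NC(=O)c1nc(Br)c2cccnc2c1N[C@H]1CC[C@H](N)CC1)c1ccc(F)cc1` — in this assay compound 2 gives "not determined" (no result reported)

Within the data shown here, compound 1 stands alone on the numbers: it is the only compound of this pair with a result in this assay, while compound 2 has no reported value and so offers no point of comparison. Nothing can therefore be said about how the two of them relate.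

Compound 3, `O=C(NCc1ccc(F)cc1)c1nc(Br)c2cccnc2c1N1CCNCC1`, has not yet been tested. Against compound 1 the change is piperazin-1-yl in place of (3-aminopropyl)amino on an aromatic carbon. The amide and the bromo group of the shared core are kept, and only the substituent on that aromatic carbon is exchanged. Among the measured compounds shown here, with no step between measured compounds to rely on, the size of this change is a matter of expectation rather than precedent. The author expects a modest shift for compound 3, most likely toward slightly weaker inhibition, but one that could well fall within the scatter, the step from compound 1 being estimated as a 1.3-fold higher number from compound 1 to compound 3 (0.12 log units; within the scatter). Compound 3 is thus expected to give about 8000 nM in this assay, with a likely range from 2500 nM to 25000 nM.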

Compound 3, half-maximal inhibitory concentration: 7000 nM
Beside the measured number, compound 3's estimate is 1.1-fold (0.06 log units) above it, within the range that was stated.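

Among these compounds, exchanging (3-aminopropyl)amino for piperazin-1-yl on this aromatic carbon, para to a bromo group, gives a 1.2-fold higher number from compound 1 to compound 3 (0.07 log units; within the scatter) in this assay and provides the first measured step at this position. The group that leaves has no ring and 2 hydrogen-bond donors, whereas the group that enters has a six-membered non-aromatic ring with 2 hetero atoms and 1 hydrogen-bond donor, yet compound 1 and compound 3 cannot be told apart on this read-out, so this single exchange gives no sign that the position distinguishes between these two groups. No measurement at hand offers an explanation for this close agreement.

What the compounds shown leave open is whether a group of another kind on this carbon, such as a morpholine ring, a dimethylamino group or a longer chain ending in a carboxylic acid, would give a step beyond the scatter. They also leave open whether the same exchange would read alike with a chlorine atom in place of the bromo group or with another amide substituent on the shared core.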